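This account rests on a few compounds, and the source may have more. Where it says the series, first, only, none or still open, it means among the compounds named here.

Measured compounds in an assay on cells for displacement of a labelled ligand from prostaglandin E2 receptor EP4 subtype (Homo sapiens), read by scintillation counting; on this read-out lower numbers stand for stronger inhibition and higher numbers for weaker inhibition:
compound 1 `Cc1oc(C(=O)O)cc1COc1ccc(-c2ccc(Cl)cc2)cc1` gives 1000 nM
compound 2 `Cc1oc(C(=O)O)cc1COc1ccc(-c2ccc(CO)cc2)cc1` gives 3000 nM
compound 3 `CNC(=O)c1ccc(-c2ccc(OCc3cc(C(=O)O)oc3C)cc2)cc1` gives > 10000 nM, a limit of this assay and not a number.

Compound 3 thus stands only as a limit on the numbers shown, with nothing tighter known. The steps into it are an at least 10-fold higher number from compound 1 to compound 3 (1.00 log units; beyond the scatter) and an at least 3.3-fold higher number from compound 2 to compound 3 (0.52 log units; beyond the scatter), both beyond the scatter, and the step of a 3.0-fold higher number from compound 1 to compound 2 (0.48 log units; beyond the scatter) runs the same way. Compound 4 `Cc1oc(C(=O)O)cc1COc1ccc(-c2ccc(S(C)(=O)=O)cc2)cc1` is not yet measured. It differs from compound 3 by methylsulfonyl in place of methylcarbamoyl on an aromatic carbon. Among the measured compounds shown here, no measured step exchanges one such group for another at this position; the three steps only show that each group placed there gave a higher number than chloro. A step from compound 3 to compound 4 beyond the scatter is therefore expected in neither direction. Because compound 3 sits at the limit of > 10000 nM in this assay, at which 1 of the 3 values shown sits, a fair chance remains that compound 4 also returns only a limit. The expected step is a number no higher from compound 3 to compound 4 (the limit leaves the size open). Compound 4 is estimated near 10000 nM, between 3000 nM and 40000 nM.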

Compound 4, inhibition constant: > 10000 nM
Compound 4: no number, only a limit; the forecaster's own chance of this, stated with the estimate: 50%; the middle value lies on the limit itself.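

In this assay compound 4 gives > 10000 nM as a limit of the assay and not a number. Methylsulfonyl on this aromatic carbon, para to a large group, gives an at least 10-fold higher number from compound 1 to compound 4 (1.00 log units; beyond the scatter) and an at least 3.3-fold higher number from compound 2 to compound 4 (0.52 log units; beyond the scatter) in the same direction as methylcarbamoyl, so a group with 0 hydrogen-bond donors ends in only a limit just as the group with 1 did. The step between the two limited compounds cannot be read, and compound 3 and compound 4 both stop at the end of the read-out: the limit of > 10000 nM in this assay, at which 2 of the 4 values shown sit.

On these data alone, how far compound 3 and compound 4 lie past that limit remains unknown, so methylsulfonyl and methylcarbamoyl cannot be ranked. Also open, as far as these compounds go, is whether fluoro, methyl, methoxy or an amine at this position would give a lower number than chloro in compound 1.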